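Swapping methyl for methoxy on the sulfonyl ring

The compounds below may be only part of what the source reports. "The series", "measured", "known", "first", "only" and "open" are said of these compounds alone.

Compound 1, `COc1ccc(Cc2nnc(NC(=O)/C(C#N)=C/c3ccccc3OS(=O)(=O)c3ccc(C)cc3)s2)cc1`, gives 70% in a functional assay on RS4-11 cells (Homo sapiens) for inhibition, read by CCK-8 assay, with a stated time of 48 h, tested at 20 uM; on this read-out lower numbers stand for less inhibition of growth and higher numbers for more inhibition of growth at the one concentration tested. Compound 2, `COc1ccc(Cc2nnc(NC(=O)/C(C#N)=C/c3ccccc3OS(=O)(=O)c3ccc(OC)cc3)s2)cc1`, gives 78% in this assay. Compound 3, `Cc1ccc(S(=O)(=O)Oc2ccccc2/C=C(\C#N)C(=O)Nc2nnc(Cc3ccccc3)s2)cc1`, gives 69% in this assay.

Compound 4, `COc1ccc(S(=O)(=O)Oc2ccccc2/C=C(\C#N)C(=O)Nc2nnc(Cc3ccccc3)s2)cc1`, has not yet been measured in this assay. It is related to compound 3 by the same change that turns compound 1 into compound 2, namely (methoxy in place of methyl on an aromatic carbon), a change that produced a number 8 percentage points higher from compound 1 to compound 2 (within the scatter). The two pairs share this change, while their cores differ by hydrogen in place of methoxy on an aromatic carbon, a difference that was accompanied by a number 1 percentage points lower from compound 1 to compound 3 (within the scatter). The place of the change is described in the same words for both pairs, so it can be called the same change rather than merely the same kind.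

The difference from compound 3 to compound 4 is methoxy in place of methyl on an aromatic carbon. Because the earlier step of a number 8 percentage points higher from compound 1 to compound 2 (within the scatter) stayed within the scatter, the step from compound 3 to compound 4 is expected to be small as well, and the estimate here is a number 6 percentage points higher from compound 3 to compound 4 (within the scatter). Since the same change on a closely related core gave only a modest shift, and all three measured numbers sit within the scatter of one another, compound 4 is expected to land near them, with an estimate of 75% and a likely range from 62% to 86%.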

Compound 4, percent growth inhibition at one concentration: 78%
The estimate for compound 4 lay 3 percentage points below the measured number; the range from low to high includes it.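

In this assay, the swap of 4-methylphenyl to 4-methoxyphenyl on the sulfonyl group gives a number 9 percentage points higher from compound 3 to compound 4 (within the scatter), and the change reads the same on both cores: the same change on two cores in this assay, a number 8 percentage points higher (within the scatter) from compound 1 to compound 2 and a number 9 percentage points higher (within the scatter) from compound 3 to compound 4, 1 percentage points apart, within the scatter of two such steps. The other difference in this set, hydrogen in place of methoxy on an aromatic carbon, gives no change at the digits printed from compound 2 to compound 4 (within the scatter), and it also reads the same on both cores: the same change on two cores in this assay, a number 1 percentage points lower (within the scatter) from compound 1 to compound 3 and no change at the digits printed (within the scatter) from compound 2 to compound 4, 1 percentage points apart, within the scatter of two such steps. Within the data shown here, every one of these steps lies within the scatter, so the agreement shows only that each change stayed small on the two cores tried; it does not show that methoxy truly alters growth inhibition, and two cores are too few to make a rule for the whole series.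

The compounds shown leave open how other groups in the same place would read, such as a chlorine, a trifluoromethyl, an amine or a carboxylic acid, and whether the methyl-to-methoxy swap would stay this small on a core carrying one of them or a longer chain. With each compound read at a single concentration, they also leave open how the four would compare across a range of concentrations.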